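Pyridin-2-yl for 2-chlorophenyl on the benzyl carbon

The compounds below may be only part of what the source reports. "The series", "measured", "known", "first", "only" and "open" are said of these compounds alone.

Measured so far:
compound 1 `O=c1cc(CN(c2ccccc2)c2cccc(Cl)c2)c2ccc(F)c(F)c2[nH]1` 1500 nM
compound 2 `O=c1cc(CN(c2cccnc2)c2cccc(Cl)c2)c2ccc(F)c(F)c2[nH]1` 77 nM
compound 3 `O=c1cc(CN(Cc2ccccc2Cl)c2cnccn2)c2ccc(F)c(F)c2[nH]1` 12 nM

In an assay on HEK293 cells for inhibition of Nitric oxide synthase, inducible (Homo sapiens), read by fluorescence (a higher number here means a weaker inhibitor, a lower number a stronger inhibitor), compound 3 gives the lowest number of the three, with compound 2 closest to it and compound 1 furthest away; both gaps lie beyond the scatter. Compound 3 and compound 2 differ in more than one place, so only their two values can be compared directly.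

Compound 4 `O=c1cc(CN(Cc2ccccn2)c2cnccn2)c2ccc(F)c(F)c2[nH]1` differs from compound 3 by one change: pyridin-2-yl in place of 2-chlorophenyl on a saturated chain carbon bound to a nitrogen on an aromatic ring. Among the compounds with values here, no measured pair shows this exact change. Within the data shown here, the only single step available, a 19-fold lower number from compound 1 to compound 2 (1.29 log units; beyond the scatter), concerns a nitrogen brought into a ring that sits directly on the ring nitrogen rather than on the saturated chain carbon, so it bears on the present step only loosely, as an example that introducing a ring nitrogen has lowered the number in this assay by a large amount. Given that loose analogy and the loss of the chlorine, a modest lowering for compound 4 is expected, a 1.5-fold lower number from compound 3 to compound 4 (0.18 log units; within the scatter), though a result within the scatter would not surprise.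

The estimate for compound 4 in this assay is 8 nM, expected to fall between 3 nM and 30 nM.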

Compound 4, half-maximal inhibitory concentration: 78 nM
The estimate for compound 4 lay 9.8-fold (0.99 log units) below the measured number; the whole stated range lies below it.
By their numbers in this assay, from the lowest: compound 3; then compounds 2 and 4 (each within the scatter of the next); then compound 1.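

At the saturated chain carbon bound to a nitrogen on an aromatic ring, the aromatic group cannot be exchanged freely: in this assay, pyridin-2-yl in place of 2-chlorophenyl gives a 6.5-fold higher number from compound 3 to compound 4 (0.81 log units; beyond the scatter). Within the data shown here, the only earlier step that brought in a ring nitrogen, on a ring sitting directly on the nitrogen, ran the opposite way, with a 19-fold lower number from compound 1 to compound 2 (1.29 log units; beyond the scatter), so across these two steps a ring nitrogen does not lower the number in every place, and compound 4 is the exception to any such reading. No measurement shown gives a reason for the rise at this position.

The step removes the chlorine and brings in the ring nitrogen together, and the compounds shown do not separate the two changes. A plain phenyl on the same carbon would show what the chlorine alone contributes, while pyridin-3-yl, pyridin-4-yl or a 3-chloropyridin-2-yl group there would show whether the outcome depends on where the ring nitrogen sits and whether a chlorine can restore the lower number.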